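From 5-chloropyridin-2-yl to 3-chloropyridin-2-yl on the amide

A few compounds are considered here, and "the series" means these few. Any claim that something is new, unique, unknown or untested is made for them only; others in the source may bear on it.

Measured compounds and their values in a functional assay on HepG2 cells (Homo sapiens) for inhibition, read by MTT assay, with a stated time of 72 h (on this read-out lower numbers stand for stronger inhibition and higher numbers for weaker inhibition), are these.
Compound 1 `Cc1noc(C)c1-c1cnc(N)c(Oc2ccc(C(=O)NC3CCCCC3)cc2)n1` gives 5420 nM
Compound 2 `Cc1noc(C)c1-c1cnc(N)c(Oc2ccc(C(=O)Nc3ccc(Cl)cn3)cc2)n1` gives 35600 nM

Of these two numbers, compound 2 has the higher, at 35600 nM in this assay and so it is the weaker inhibitor of the pair. Compound 3 `Cc1noc(C)c1-c1cnc(N)c(Oc2ccc(C(=O)Nc3ncccc3Cl)cc2)n1` has the same atoms as compound 2, joined differently, with this difference 3-chloropyridin-2-yl in place of 5-chloropyridin-2-yl on an amide-type nitrogen and the change sits on an amide-type nitrogen. Among the measured compounds shown here, only one measured step bears on it, namely a 6.6-fold higher number from compound 1 to compound 2 (0.82 log units; beyond the scatter) and that modest step exchanged cyclohexyl for 5-chloropyridin-2-yl, a different kind of change. For the measured compounds named here, no measured step shows what this exchange of chloropyridinyl groups does. A smaller step is therefore expected in this assay and probably none beyond the scatter, with a slight lean towards a lower number. The estimated step is a 1.4-fold lower number from compound 2 to compound 3 (0.15 log units; within the scatter) in this account. Compound 3 is expected at 25000 nM with a range from 8000 nM to 70000 nM on this estimate.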

Compound 3, half-maximal inhibitory concentration: 27200 nM
Estimate against measurement, compound 3: 1.1-fold (0.04 log units) below, and the stated range covers the measured number.
By their numbers in this assay, from the lowest: compound 1; then compounds 3 and 2 (each within the scatter of the next).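

In this assay, 3-chloropyridin-2-yl in place of 5-chloropyridin-2-yl on the amide-type nitrogen gives a 1.3-fold lower number from compound 2 to compound 3 (0.12 log units; within the scatter), so this rearrangement of the same atoms has no effect that can be told from the scatter. With a 5.0-fold higher number from compound 1 to compound 3 (0.70 log units; beyond the scatter), a second chloropyridinyl group also gives a higher number than cyclohexyl, which shows that the earlier step was not confined to 5-chloropyridin-2-yl. No measurement offered here explains this result.

The compounds shown leave open what a pyridin-2-yl group without chlorine or a plain phenyl group would give on this nitrogen, and so whether the gap to compound 1 goes with the aromatic ring or with the chlorine. They also leave open how cyclopentyl or a longer alkyl chain would compare with cyclohexyl in this assay.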